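Bromo for Fluoro on a Sulfonyl Aryl Ring

This account rests on a few compounds, and the source may have more. Where it says the series, first, only, none or still open, it means among the compounds named here.

Compound 1 `CN1CCN(c2ccc(C3=NN(S(=O)(=O)c4ccc(F)cc4)C(c4ccc(N(C)C)cc4)C3)cc2)CC1` and compound 2 `CN1CCN(c2ccc(C3=NN(S(=O)(=O)c4ccc(Br)cc4)C(c4ccc(N(C)C)cc4)C3)cc2)CC1` differ only by bromo in place of fluoro on an aromatic carbon. In a functional assay on MDA-MB-231 cells (Homo sapiens) for inhibition, read by sulforhodamine B assay, tested at 10 uM (on this read-out lower numbers stand for less inhibition and higher numbers for more inhibition at the one concentration tested (going by the name of the read-out)), compound 1 gives 15.7%, and compound 2 gives 23.7%, so this change made a number 8 percentage points higher from compound 1 to compound 2 (within the scatter). Compound 3 `CN(C)c1ccc(C2CC(c3ccc(-n4cncn4)cc3)=NN2S(=O)(=O)c2ccc(F)cc2)cc1` has a different core: relative to compound 1 it carries 1H-1,2,4-triazol-1-yl in place of 4-methylpiperazin-1-yl on an aromatic carbon, and in this assay compound 3 gives 12.1%, which is a number 3.6 percentage points lower from compound 1 to compound 3 (within the scatter). Compound 4 `CN(C)c1ccc(C2CC(c3ccc(-n4cncn4)cc3)=NN2S(=O)(=O)c2ccc(Br)cc2)cc1` has not been measured; it stands to compound 3 as compound 2 stands to compound 1, the change being bromo in place of fluoro on an aromatic carbon at the same place in the same words. The step from compound 3 to compound 4 is therefore expected to be a number 7.9 percentage points higher from compound 3 to compound 4 (within the scatter) in this assay, resting on the earlier step of a number 8 percentage points higher from compound 1 to compound 2 (within the scatter). Compound 4 is estimated at 20%, expected to lie between 8% and 32%.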

Compound 4, a percentage reported as inhibition, at one concentration (the size of the read-out at that concentration, not a potency): 10.4%
For compound 4 the middle estimate is 9.6 percentage points above the measured one; the measured number falls inside the stated range.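

In this assay, carrying bromo in place of fluoro over to the second core gave a number 1.7 percentage points lower from compound 3 to compound 4 (within the scatter), and this step does not differ from the earlier one: the same change on two cores in this assay, a number 8 percentage points higher (within the scatter) from compound 1 to compound 2 and a number 1.7 percentage points lower (within the scatter) from compound 3 to compound 4, 9.7 percentage points apart, within the scatter of two such steps. The exchange of 4-methylpiperazin-1-yl for 1H-1,2,4-triazol-1-yl, read among the bromo compounds, gave a number 13.3 percentage points lower from compound 2 to compound 4 (beyond the scatter), yet it too does not differ from its counterpart among the fluoro compounds: the same change on two cores in this assay, a number 3.6 percentage points lower (within the scatter) from compound 1 to compound 3 and a number 13.3 percentage points lower (beyond the scatter) from compound 2 to compound 4, 9.7 percentage points apart, within the scatter of two such steps. This shows no dependence of the bromo-for-fluoro change on the core across these two cores, but it does not show that the change moves the number on either core, and two cores cannot establish a rule for the series.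

Going by these compounds, whether chloro or methoxy in that place would behave alike remains open. So does whether a morpholine in place of the 4-methylpiperazin-1-yl group would do so.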